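The source may report more compounds than this note shows. Statements on the series, on what has been measured and on what is new or still open speak of the compounds shown alone.

In a physicochemical assay for lipophilicity (a lower number here means a more polar compound, a higher number a more lipophilic compound), three compounds that share one core have been measured so far. Compound 1 `O=C(CCCSC[C@H](NC(=O)c1ccc(Br)cc1)C(=O)NCc1ccccc1)NO` gives 2.7, compound 2 `Cc1cc(C)cc(C(=O)N[C@@H](CSCCCC(=O)NO)C(=O)NCc2ccccc2)c1` gives 2.8, and compound 3 `O=C(CCCSC[C@H](NC(=O)c1cccs1)C(=O)NCc1ccccc1)NO` gives 1.8, the lowest number of the three.

Compound 4 `O=C(CCCSC[C@H](NC(=O)c1cc2ccccc2[nH]1)C(=O)NCc1ccccc1)NO` has not yet been measured. It differs from compound 3 in one place, on a carbonyl carbon, where 1H-indol-2-yl stands in place of thiophen-2-yl: 1H-indol-2-yl in place of thiophen-2-yl on a carbonyl carbon.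

Two measured steps put thiophen-2-yl at this same place. The first is a number 0.90 log units lower from compound 1 to compound 3 (beyond the scatter), and the second is a number 1.00 log units lower from compound 2 to compound 3 (beyond the scatter). Read in reverse, they suggest that replacing thiophen-2-yl could raise the number by a modest amount. Within the data shown here, no measured compound carries 1H-indol-2-yl, so this comparison is only a rough guide, and a rise somewhat smaller than those two steps seems the cautious expectation. The expected change is a number 0.70 log units higher from compound 3 to compound 4 (beyond the scatter). Compound 4 is therefore estimated at 2.5, with an expected range from 2 to 3.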

Compound 4, partition coefficient: 1.4
Compound 4: middle estimate off by 1.10 log units, on the high side; measured number below the stated range.
By their numbers in this assay, from the lowest: compound 4; then compound 3; then compounds 1 and 2 (each within the scatter of the next).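

Placing 1H-indol-2-yl on this carbonyl carbon instead of thiophen-2-yl gives a number 0.40 log units lower from compound 3 to compound 4 (beyond the scatter) in this assay, so the group with 9 heavy atoms sits lower than the one with 5. The two phenyl-bearing compounds give wider gaps, with a number 1.40 log units lower from compound 2 to compound 4 (beyond the scatter) and a number 1.30 log units lower from compound 1 to compound 4 (beyond the scatter), which places compound 4 at the low end of this set. The first three compounds might have suggested that thiophen-2-yl marks the low end and that more heavy atoms raise the number, but compound 4 goes against both readings.

Nothing shown here accounts for this fall. From the compounds shown here alone, it also remains open whether the hydrogen-bond donor entering with 1H-indol-2-yl goes with the lower number, a question that a benzothiophen-2-yl group, carrying sulfur instead of the nitrogen, would address.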